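Swapping methoxy for chloro on a carbamate phenyl ring

The source may hold more compounds than are shown below. What is called first, only, known or untested is meant among the compounds shown, and "the series" means these compounds.

Measured so far:
compound 1, `COc1ccc(OC(=O)Nc2ccc([Se]C#N)cc2)cc1` — 25200 nM
compound 2, `CCCCCCOC(=O)Nc1ccc([Se]C#N)cc1` — 2800 nM
compound 3, `N#C[Se]c1ccc(NC(=O)OCc2ccc([N+](=O)[O-])cc2)cc1` — 7700 nM

All three share a selenocyanate-bearing anilide core and differ only in the group attached through the carbamate oxygen. In an ADME assay on BEAS-2B cells (Homo sapiens) for cytotoxicity, read by MTT assay, with a stated time of 72 h (on this read-out higher numbers stand for weaker inhibition of growth and lower numbers for stronger inhibition of growth), compound 1 gives 25200 nM, the highest of the three numbers, so it inhibits the growth of these cells least. Its nearest neighbour is compound 3 with 7700 nM, a gap beyond the scatter, and compound 2 with 2800 nM lies further still.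

Compound 4, `N#C[Se]c1ccc(NC(=O)Oc2ccc(Cl)cc2)cc1`, is compound 1 with one change: chloro in place of methoxy on an aromatic carbon. Among the measured compounds shown here, no measured pair shows this exact swap, so the size of the step from compound 1 to compound 4 in this assay cannot be read off the data. Since compound 2 and compound 3 both sit below compound 1, a modest move toward stronger inhibition, or no change beyond the scatter, is the expectation; the expected step is a 1.7-fold lower number from compound 1 to compound 4 (0.23 log units; within the scatter). Compound 4 is therefore estimated at 15000 nM, within a range from 6000 nM to 40000 nM.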

Compound 4, concentration for 50% growth inhibition: 9300 nM
For compound 4 the middle estimate is 1.6-fold (0.21 log units) above the measured one, and the stated range covers the measured number.
By their numbers in this assay, from the lowest: compound 2; then compounds 3 and 4 (each within the scatter of the next); then compound 1.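

In this assay the swap of methoxy for chloro on an aromatic carbon, para to a large group, gives a 2.7-fold lower number from compound 1 to compound 4 (0.43 log units; beyond the scatter) and so shows that this place on the ring is not silent. A single small substituent there is enough to move the number beyond the scatter. The earlier compounds shown here could not show this, as they differ from each other in the whole group on the carbamate oxygen, and no pair among them isolates one small change. No measurement shown here accounts for the size or direction of this step.

One swap cannot separate the effect of adding chloro from that of losing methoxy. On these data alone, it also remains open how the number would respond to a hydrogen, a fluoro group or an amine at this same place.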